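Thiazoline to Imidazole Swap on the Thioether Arm

A few compounds are considered here, and "the series" means these few. Any claim that something is new, unique, unknown or untested is made for them only; others in the source may bear on it.

Measured compounds:
compound 1 `Cn1c(-c2ccc(NC(=O)CCl)cc2)nc(-c2ccccc2)c1-c1ccccc1`: 15.1%
compound 2 `Cn1c(-c2ccc(NC(=O)CSC3=NCCS3)cc2)nc(-c2ccccc2)c1-c1ccccc1`: 31%

For the measured compounds named here, in a functional assay on HT-29 cells (Homo sapiens) for cytotoxicity, read by MTT assay, with a stated time of 24 h, tested at 6.4 ug/mL (on this read-out higher numbers stand for a stronger effect at the one concentration tested and lower numbers for a weaker effect), compound 2 gives the higher of the two numbers; compound 1 sits a number 15.9 percentage points higher from compound 1 to compound 2 (beyond the scatter) beneath it, the only measured step, in which the thiazoline-bearing thioether replaced a chlorine. Compound 3 `Cn1ccnc1SCC(=O)Nc1ccc(-c2nc(-c3ccccc3)c(-c3ccccc3)n2C)cc1` keeps the chloroacetamide-derived thioether of compound 2 and changes only the ring on the sulfur: a group of 6 heavy atoms (4 carbon, 2 nitrogen; one five-membered aromatic ring with 2 hetero atoms) in place of a group of 5 heavy atoms (3 carbon, 1 nitrogen, 1 sulfur; one five-membered non-aromatic ring with 2 hetero atoms), on a sulfur. Going by the values given here, no measured step compares two different rings on this sulfur, so the one step gives only indirect guidance: it shows that a sulfur-linked five-membered ring at this position raises the number modestly, and it says nothing about whether an aromatic ring does so more or less than a non-aromatic one. Compound 3 is therefore expected near compound 2, within the scatter, at a number 3 percentage points lower from compound 2 to compound 3 (within the scatter). The estimate for compound 3 is 28%, within 12% to 45%.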

Compound 3, a percentage reported as activity, at one concentration (the size of the read-out at that concentration, not a potency): 30.7%
Beside the measured number, compound 3's estimate is 2.7 percentage points below it; the measured number falls inside the stated range.
By their numbers in this assay, from the lowest: compound 1; then compounds 3 and 2 (each within the scatter of the next).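

In this assay, exchanging the ring on the sulfur gives a number 0.3 percentage points lower from compound 2 to compound 3 (within the scatter), so at this position 1-methyl-1H-imidazol-2-yl, a five-membered aromatic ring, and the five-membered non-aromatic ring it replaces cannot be told apart. Placing (1-methyl-1H-imidazol-2-yl)sulfanyl on the saturated chain carbon in place of chloro gives a number 15.6 percentage points higher from compound 1 to compound 3 (beyond the scatter), which shows that the gain over the chloro group is not confined to the non-aromatic ring. Nothing available explains these numbers.

Whether any ring on the sulfur is needed for this gain remains open, since the compounds shown do not tell what a simple ethyl group or a carboxylic acid on a short chain would give there. As far as these compounds go, how these compounds compare at other concentrations also remains open.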